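Compound 4 against a series held at the limit

The source may hold more compounds than are shown below. What is called first, only, known or untested is meant among the compounds shown, and "the series" means these compounds.

Measured in a functional assay on Raji cells (Homo sapiens) for antiproliferative activity, read by MTT assay; a lower number here means a stronger inhibitor, a higher number a weaker inhibitor:
- compound 1 `COc1ncc(-c2ccc3ncnc(N[C@H]4CCCN(C(=O)c5cccnc5)C4)c3c2)cc1C#N`: > 10000 nM
- compound 2 `COc1ncc(-c2ccc3ncnc(N[C@H]4CCCN(C(=O)CN(C)C)C4)c3c2)cc1C#N`: > 10000 nM
- compound 3 `COc1ncc(-c2ccc3ncnc(N[C@H]4CCCN(C(=O)C(C)N)C4)c3c2)cc1C#N`: > 10000 nM

All three entries are limits and not numbers, as the limit of > 10000 nM in this assay, at which 3 of the 3 values shown sit, shows. In this assay, as far as these compounds go, compound 3 gives > 10000 nM, which is only a limit, so its true position is unknown.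

The next compound is compound 4 `COc1ncc(-c2ccc3ncnc(N[C@H]4CCCN(C(=O)c5coc([N+](=O)[O-])c5)C4)c3c2)cc1C#N`. It carries 5-nitrofuran-3-yl in place of 1-aminoethyl on a carbonyl carbon.

Going by the values given here, three measured steps bear on this change: a step that the two limits leave unreadable from compound 1 to compound 2, a step that the two limits leave unreadable from compound 1 to compound 3 and a step that the two limits leave unreadable from compound 2 to compound 3. None of them has a readable size, so they give no direction. Among the compounds with values here, compound 1 is the only measured compound with an aromatic ring on that carbonyl carbon, and its > 10000 nM is also a limit. Swapping between pyridin-3-yl, (dimethylamino)methyl and 1-aminoethyl has therefore not moved any compound off the limit.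

On that basis, no step beyond the scatter is expected in this assay, and the estimated change is a number no higher from compound 3 to compound 4 (the limit leaves the size open). Within the data shown here, a gain cannot be excluded, as no measured compound carries 5-nitrofuran-3-yl. For compound 4 the expected value is 10000 nM, with an estimated range of 2500 nM to 30000 nM.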

Compound 4, half-maximal inhibitory concentration: > 10000 nM
Compound 4: a limit, no number; the forecaster's own chance of this, stated with the estimate: 75%; the middle value lies on the limit itself.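

In this assay compound 4 gives > 10000 nM as a limit and not a number. Going by these compounds alone, its steps from compound 1, compound 2 and compound 3 therefore cannot be read, and no new step follows. The series remains at one limit: the limit of > 10000 nM in this assay, at which 4 of the 4 values shown sit.

The compounds shown leave open how far each of the four lies from that limit, and which group on the carbonyl carbon, if any, would give a measurable value.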